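The compounds below may be only part of what the source reports. "The series", "measured", "known", "first", "only" and "open" are said of these compounds alone.

Compound 3 (`CC[C@@H]1CC[C@@H](C(=O)N2CCN(C(C)=O)[C@H](C)C2)N1C(=O)C1=C(C(C)C)N2C(=N[C@@](C)(c3ccc(Cl)cc3)[C@H]2c2ccc(Cl)cc2)S1`) stands at 59% in an ADME assay on microsomes from liver (Mus musculus) for metabolic stability, read by LC-MS, with a stated time of 30 min, tested at 1 uM; a higher number here means that more of the compound is left, a lower number that less of the compound is left. Compound 1 (`CC(=O)N1CCN(C(=O)[C@@H]2CC[C@@H](C)N2C(=O)C2=C(C(C)C)N3C(=N[C@@](C)(c4ccc(Cl)cc4)[C@H]3c3ccc(Cl)cc3)S2)C[C@@H]1C`) gives 65%. The gap between compound 1 and compound 3 lies within the scatter. Compound 2 (`CC[C@@H]1CC[C@@H](C(=O)N2CCN(C)[C@H](C)C2)N1C(=O)C1=C(C(C)C)N2C(=N[C@@](C)(c3ccc(Cl)cc3)[C@H]2c2ccc(Cl)cc2)S1`) gives 76%. The gap between compound 2 and compound 3 lies beyond the scatter, with compound 2 on the higher side. Compound 4 (`CC[C@@H]1CC[C@@H](C(=O)N2CCN(C(C)=O)[C@@H](C)C2)N1C(=O)C1=C(C(C)C)N2C(=N[C@@](C)(c3ccc(Cl)cc3)[C@H]2c2ccc(Cl)cc2)S1`) departs from compound 3 in one place (the two compounds have the same atoms and bonds and differ only in configuration as drawn: 1 of 5 stereo elements differ; a stereocentre at a saturated ring carbon is drawn R in compound 3 and S in compound 4). Among the measured compounds shown here, the one measured single change is a number 17 percentage points lower from compound 2 to compound 3 (beyond the scatter) for acetyl in place of methyl on an amine nitrogen in a ring, and it is no change of configuration, so it offers only indirect guidance. For the measured compounds named here, no measured pair differs in configuration alone, so this assay is expected to show no step beyond the scatter, with an estimated a number 1 percentage points lower from compound 3 to compound 4 (within the scatter) as its size. For compound 4 the expected value is 58% with an estimated range from 45% to 72% in this measurement.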

Compound 4, percent of the compound remaining: 54%
Beside the measured number, compound 4's estimate is 4 percentage points above it; the measured number falls inside the stated range.
By their numbers in this assay, from the lowest: compounds 4, 3 and 1 (each within the scatter of the next, the first and the last beyond it); then compound 2.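

Among the compounds shown here, the step of a number 5 percentage points lower from compound 3 to compound 4 (within the scatter) in this assay is the first reading of a change of configuration alone, and it shows that turning this saturated ring carbon from R to S stays within the scatter. The comparison is clean on one point: the fact that compounds 3 and 4 differ only in the configuration as drawn. Two steps to the S form do exceed the scatter: a number 22 percentage points lower from compound 2 to compound 4 (beyond the scatter) with the larger group on the carbonyl carbon, and a number 11 percentage points lower from compound 1 to compound 4 (beyond the scatter) with methyl in place of hydrogen on a saturated chain carbon.

Going by these compounds, it remains open whether configuration at this carbon would count equally little with methyl rather than acetyl on the ring nitrogen. Also open, on these data alone, is what an ethyl group at this stereocentre would do.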